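The source may report more compounds than this note shows. Statements on the series, on what has been measured and on what is new or still open speak of the compounds shown alone.

Going by the values given here, two analogues of the shared core have numbers so far. Compound 1 `CCN1CCc2c(sc(NC(=O)Nc3ccc(I)cc3)c2C(N)=O)C1` is the lower of the two: in a functional assay (strain AB) with Danio rerio as the target, read by microscopy, with a stated time of 1 h (on this read-out higher numbers stand for an effect only at larger amounts of compound and lower numbers for an effect already at smaller amounts), compound 1 gives 1620 nM. Compound 2 `CCN1CCc2c(sc(NC(=O)Nc3ccc(-c4ccccc4)cc3)c2C(N)=O)C1`, which carries phenyl in place of iodo on an aromatic carbon, gives 3390 nM; the step of a 2.1-fold higher number from compound 1 to compound 2 (0.32 log units; beyond the scatter) is modest.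

Compound 3 `CCN1CCc2c(sc(NC(=O)NCc3cccc(Cl)c3)c2C(N)=O)C1` is not yet measured. Change: 3-chlorobenzyl in place of 4-iodophenyl on an amide-type nitrogen. Among the compounds with values here, no measured step touches the amide-type nitrogen or a benzyl group, so the step from compound 1 is only loosely anchored. Within the data shown here, the one known step suggests that enlarging this part of the molecule costs somewhat, so a modest rise is expected, a 1.5-fold higher number from compound 1 to compound 3 (0.19 log units; within the scatter). For compound 3 the expected value is 2500 nM, with a range from 800 nM to 8000 nM.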

Compound 3, half-maximal effective concentration: > 25000 nM
Compound 3: no number, only a limit; the forecaster's own chance of this, stated with the estimate: 10%; middle value at least 10-fold (1.00 log units) from the limit.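

Swapping 4-iodophenyl for 3-chlorobenzyl on the amide-type nitrogen gives the only large step so far: in this assay there is an at least 15-fold higher number from compound 1 to compound 3 (1.18 log units; beyond the scatter). Compound 3 has only a limit, not a number: the limit of > 25000 nM in this assay, at which 1 of the 3 values shown sits. Although both groups hold one six-membered aromatic ring of carbon only, this position proves far more sensitive to change than the earlier step suggested, a 2.1-fold higher number from compound 1 to compound 2 (0.32 log units; beyond the scatter).

The compounds shown do not separate the benzyl link from the change of halogen and its place. As far as these compounds go, how an amine, a carboxylic acid or a longer chain on this nitrogen would read remains open.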